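A few compounds are considered here, and "the series" means these few. Any claim that something is new, unique, unknown or untested is made for them only; others in the source may bear on it.

Going by the values given here, in a functional assay on HSC-4 cells (Homo sapiens) for cytotoxicity, with a stated time of 24 h (a lower number here means that less compound is tolerated, a higher number that more compound is tolerated), compound 2 (`O=C1/C(=C/c2ccccc2)CCC/C1=C\c1cccc([N+](=O)[O-])c1`) gives 2400 nM, the lower of the two numbers known so far. Compound 1 (`COc1ccc(/C=C2\CCC/C(=C\c3ccccc3[N+](=O)[O-])C2=O)cc1`) gives 24000 nM, and that gap lies beyond the scatter. Compound 3 (`COc1ccc(/C=C2\CCC/C(=C\c3cccc([N+](=O)[O-])c3)C2=O)cc1`) departs from compound 2 in one place: methoxy in place of hydrogen on an aromatic carbon. Among the compounds with values here, no measured pair isolates this change, so in this assay only a modest rise in the number is expected, smaller than the gap between the two measured compounds. The expected change is a 1.7-fold higher number from compound 2 to compound 3 (0.22 log units; within the scatter). For compound 3 the estimated value is 4000 nM, within an expected range of 1300 nM to 12000 nM.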

Compound 3, half-maximal cytotoxic concentration: 11000 nM
The estimate for compound 3 lay 2.8-fold (0.44 log units) below the measured number, within the range that was stated.
By their numbers in this assay, from the lowest: compound 2; then compound 3; then compound 1.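

In this assay, methoxy in place of hydrogen on an aromatic carbon, para to a large group, gives a 4.6-fold higher number from compound 2 to compound 3 (0.66 log units; beyond the scatter). Going by these compounds alone, this is the first single-place reading of the change from phenyl to 4-methoxyphenyl, and it shows that at this position methoxy goes with more compound being tolerated. Nothing available explains this rise.

From the compounds shown here alone, whether an amine, a hydroxyl or an ethoxy group at this position would move the number the same way stays open. Also open, going by these compounds, is whether hydrogen in place of methoxy would lower the number in the same way on the core of compound 1.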